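The source may hold more compounds than are shown below. What is called first, only, known or untested is meant among the compounds shown, and "the series" means these compounds.

Two ureas of the shared core have been measured in a functional assay on CRL2813 cells (Homo sapiens) for cytotoxicity, read by sulforhodamine B assay, with a stated time of 5 days; a lower number here means a stronger inhibitor, a higher number a weaker inhibitor. Compound 1 `O=C(Nc1ccccc1C(=O)O)N[C@H]1CC[C@@H](Oc2ccc(F)cc2)CC1` reaches only the limit of the assay, > 20000 nM. Compound 2 `CSc1ccc(NC(=O)N[C@H]2CC[C@H](Oc3ccc(F)cc3)CC2)cc1` likewise returns a limit rather than a number, > 20000 nM. Among the compounds with values here, compound 2 therefore stands at the limit itself: the limit of > 20000 nM in this assay, at which 2 of the 2 values shown sit, covers both readings, so no step between measured compounds can be placed and no direction has yet been seen. Compound 3 `COc1ccccc1NC(=O)N[C@H]1CC[C@H](Oc2ccc(F)cc2)CC1` is the next member and differs from compound 2 in one place, (2-methoxyphenyl in place of 4-(methylsulfanyl)phenyl on an amide-type nitrogen). Within the data shown here, with no measured step to guide the size, the expectation is no change beyond the scatter, since both readings so far are limits and the pair gives no sign that this exchange brings the series into the measurable range. The step expected in this assay is a step that the limit leaves unreadable from compound 2 to compound 3. Compound 3 is estimated at 25000 nM, with a range from 8000 nM to 60000 nM, and most likely reported again as a limit.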

Compound 3, half-maximal inhibitory concentration: > 20000 nM
Compound 3 gave a limit, no number (the forecaster's own chance of this, stated with the estimate: 75%); the middle value is on the limit's open side.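

Compound 3, like compound 2, returns a limit and not a number, so no step between compound 2 and compound 3 can be read: the limit of > 20000 nM in this assay, at which 3 of the 3 values shown sit.

The compounds shown leave open whether any urea of the shared core gives a measurable value in this assay.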